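Aryl swap on the formamidine of compound 1

This account rests on a few compounds, and the source may have more. Where it says the series, first, only, none or still open, it means among the compounds named here.

Within the data shown here, compound 1 `CCOC(=O)C1=C(N/C=N/c2cccnc2Cl)Nc2[nH]nc(C)c2C1c1ccc(N(C)C)cc1` gives 4630 nM in a functional assay on HeLa cells (Homo sapiens) for inhibition, read by MTT assay, with a stated time of 48 h (a higher number here means a weaker inhibitor, a lower number a stronger inhibitor), and holds the lowest of the two numbers measured so far. Among the measured compounds shown here, compound 2 `CCOC(=O)C1=C(N/N=C(/Br)c2ccccc2)Nc2[nH]nc(C)c2C1c1ccc(N(C)C)cc1` gives 75700 nM in this assay; the step of a 16-fold higher number from compound 1 to compound 2 (1.21 log units; beyond the scatter) is the only measured step, and it exchanges the whole group on the amine nitrogen rather than the aryl ring alone. Compound 3 `CCOC(=O)C1=C(N/C=N/c2ccc([N+](=O)[O-])cc2)Nc2[nH]nc(C)c2C1c1ccc(N(C)C)cc1` differs from compound 1 in one place: 4-nitrophenyl in place of 2-chloropyridin-3-yl on a double-bonded nitrogen. For the measured compounds named here, that change keeps the carbon with a double bond to nitrogen in place, so the measured step bears on it only loosely; no step shows what a change of aryl ring on that nitrogen does. The step of a 1.3-fold higher number from compound 1 to compound 3 (0.11 log units; within the scatter) is therefore expected to be small and of uncertain direction, carrying a wide range. For compound 3 the estimate in this assay is 6000 nM, between 1500 nM and 25000 nM.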

Compound 3, half-maximal inhibitory concentration: 57800 nM
Beside the measured number, compound 3's estimate is 9.6-fold (0.98 log units) below it, outside the stated range (above it).
By their numbers in this assay, from the lowest: compound 1; then compounds 3 and 2 (each within the scatter of the next).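

In this assay, the aryl group on the double-bonded nitrogen proves to matter: with the carbon with a double bond to nitrogen kept in place, 4-nitrophenyl in place of 2-chloropyridin-3-yl gives a 12-fold higher number from compound 1 to compound 3 (1.10 log units; beyond the scatter), a large step from one change alone. The exchange of the whole group on the amine nitrogen gives a 1.3-fold lower number from compound 2 to compound 3 (0.12 log units; within the scatter), so a step of the size seen earlier does not need that whole exchange and is reached by the aryl change alone. No evidence at hand bears on the origin of this step.

As far as these compounds go, the change removes the ring nitrogen and the chlorine and brings in the nitro group all at once, so the share of each stays open. An unsubstituted pyridine ring, or an amine on the phenyl ring, on that nitrogen would begin to separate them.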